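This account rests on a few compounds, and the source may have more. Where it says the series, first, only, none or still open, it means among the compounds named here.

Measured so far in a functional assay on the whole organism with Rattus norvegicus as the target, in the glucose tolerance test; a higher number here means that more compound is needed for the effect, a lower number that less compound is needed:
compound 1 `CCCCCCCCCCCCCCC1(C(N)=O)CO1`: 10 mg/kg
compound 2 `CCCCCCC1(C(=O)OC)CO1`: 10 mg/kg
compound 3 `CCCCCCCCCCCCCCC1(C(=O)N(C)C)CO1`: 25 mg/kg

Compound 2 stands level with compound 1 at the digits recorded, the two of them together giving the lowest numbers of the three; the nearest number is that of compound 1, with no change at the digits recorded, and the furthest is that of compound 3, which lies a modest way higher, beyond the scatter. For the measured compounds named here, the one single-point step available, a 2.5-fold higher number from compound 1 to compound 3 (0.40 log units; beyond the scatter), concerns the group on the carbonyl carbon and does not touch the chain.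

Compound 4 `CCCCCCCCCCCCC1(C(=O)OC)CO1` is the next member to be tested. It differs from compound 2 as follows: hexyl in place of hydrogen on a saturated chain carbon, six bonds along the chain from a saturated ring carbon. Going by the values given here, no measured step changes the chain alone, so no direct precedent exists. Compound 1 and compound 2 differ both in the chain and in the group on the carbonyl carbon, and their numbers are level; this does not isolate the chain, but it gives no sign that the chain shifts the read-out. The step from compound 2 to compound 4 is therefore expected to stay within the scatter, with no direction preferred: no change at the digits printed from compound 2 to compound 4 (within the scatter). Compound 4 is estimated at 10 mg/kg, within the range 5 mg/kg to 25 mg/kg.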

Compound 4, minimum effective dose: 5 mg/kg
The estimate for compound 4 lay 2.0-fold (0.30 log units) above the measured number; measured number inside the range.
By their numbers in this assay, from the lowest: compounds 4, 1 and 2 (each within the scatter of the next); then compound 3.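

In this assay, hexyl in place of hydrogen on a saturated chain carbon, six bonds along the chain from a saturated ring carbon, gives a 2.0-fold lower number from compound 2 to compound 4 (0.30 log units; within the scatter). For the compounds shown here, this is the first step that changes the chain alone, with the group on the carbonyl carbon held constant, so the chain can now be read directly rather than through a pair that differs in two places. At this position the added hexyl leaves the minimum effective dose within the scatter, so the two compounds cannot be ranked, and nothing available bears on the reason for this outcome.

Going by these compounds, whether a still longer chain, or a chain carrying an amine or a terminal carboxylic acid, would keep the number within the scatter remains open, since a single step defines no trend along the chain. Also open, on these data alone, is whether the change on the carbonyl carbon seen in a 2.5-fold higher number from compound 1 to compound 3 (0.40 log units; beyond the scatter) holds on other chain lengths, and how a carboxylic acid in that place would read.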